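Amide-nitrogen heteroaryl swaps in the thienylmethyl amide series

A few compounds are considered here, and "the series" means these few. Any claim that something is new, unique, unknown or untested is made for them only; others in the source may bear on it.

Among the compounds with values here, compound 3 `Cc1ccc(OCC(=O)N(Cc2cccs2)c2cnn(C)c2)cc1` gives 63000 nM in an assay on HEK293 cells for agonist activity at transient receptor potential cation channel subfamily M member 8 (Homo sapiens), read by fluorescence and calcium flux, with a stated time of 15 min (on this read-out lower numbers stand for an effect already at smaller amounts and higher numbers for an effect only at larger amounts of compound), the highest of the three numbers measured so far. Compound 1 `Cc1ccc(OCC(=O)N(Cc2cccs2)c2ccnn2C)cc1` gives 422 nM and compound 2 `Cc1ccc(OCC(=O)N(Cc2cccs2)c2nccn2C)cc1` gives 1790 nM. The steps of a 150-fold higher number from compound 1 to compound 3 (2.17 log units; beyond the scatter) and a 35-fold higher number from compound 2 to compound 3 (1.55 log units; beyond the scatter) were large, whereas a 4.2-fold higher number from compound 1 to compound 2 (0.63 log units; beyond the scatter) was only modest. Compound 4 `Cc1ccc(OCC(=O)N(Cc2cccs2)c2ncccn2)cc1` is not yet measured; the change from compound 3 is pyrimidin-2-yl in place of 1-methyl-1H-pyrazol-4-yl on an amide-type nitrogen. Within the data shown here, no measured step covers pyrimidin-2-yl itself, but the two steps into compound 3 show that each other aromatic group tried on this nitrogen gave a markedly lower number, so a lower number for compound 4 than for compound 3, of a size comparable to those steps, is expected. Compound 4 is therefore estimated at 1500 nM in this assay, between 300 nM and 8000 nM, which corresponds to an expected 42-fold lower number from compound 3 to compound 4 (1.62 log units; beyond the scatter).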

Compound 4, half-maximal effective concentration: 3700 nM
For compound 4 the middle estimate is 2.5-fold (0.39 log units) below the measured one; the range from low to high includes it.
By their numbers in this assay, from the lowest: compound 1; then compound 2; then compound 4; then compound 3.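

The step of a 17-fold lower number from compound 3 to compound 4 (1.23 log units; beyond the scatter) shows that a six-membered aromatic ring without a methyl group can take the place of 1-methyl-1H-pyrazol-4-yl on the amide-type nitrogen and recover much of the lost ground. That recovery is incomplete, with a 2.1-fold higher number from compound 2 to compound 4 (0.32 log units; beyond the scatter) and an 8.8-fold higher number from compound 1 to compound 4 (0.94 log units; beyond the scatter) in this assay, so 1-methyl-1H-pyrazol-5-yl still gives the lowest number of the four groups. No evidence explains these differences.

Open, from the compounds shown here alone, is whether a pyridin-2-yl or a plain phenyl group on this nitrogen would come closer to compound 1, and whether an amine on the pyrimidin-2-yl ring would shift the number of compound 4.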